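The compounds below may be only part of what the source reports. "The series", "measured", "known", "first", "only" and "open" are said of these compounds alone.

Compound 1 `O=C(Cn1c(=O)oc2cc(Cl)ccc21)NCc1cccs1`: 20.3%
Compound 2 `O=C(Cn1c(=O)oc2ccccc21)NCc1ccccn1`: 37.3%
Compound 3 `O=C(Cn1c(=O)oc2cc(Cl)ccc21)Nc1cc(C(F)(F)F)ccc1Cl`: 1.61%

Of the compounds shown here, three have so far been measured in an ADME assay on RAW264.7 cells (Mus musculus) for cytotoxicity, read by MTT assay, with a stated time of 72 h, tested at 50 uM; on this read-out lower numbers stand for a weaker effect and higher numbers for a stronger effect at the one concentration tested. Compound 2 gives the highest of the three numbers, 37.3%. Compound 1 stands nearest to it, a reading beyond the scatter below it, and compound 3 stands furthest, well below both.

Compound 4 `O=C(Cn1c(=O)oc2ccccc21)Nc1ccccc1` has not been measured. Compared with compound 2, it carries phenyl in place of (pyridin-2-yl)methyl on an amide-type nitrogen. Among the measured compounds shown here, no two measured compounds differ in only one place, so no measured step gives the size of such a change directly. For the measured compounds named here, compound 3, the only other measured compound whose amide nitrogen carries an aromatic ring directly, gives 1.61%, though it also differs from compound 4 in its core and in the groups on that ring. In this assay the expected step is a number 22.3 percentage points lower from compound 2 to compound 4 (beyond the scatter), downward and beyond the scatter. Compound 4 is accordingly estimated at 15%, within a range from 0% to 32%.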

Compound 4, a percentage reported as inhibition, at one concentration (the size of the read-out at that concentration, not a potency): 35.1%
Compound 4: middle estimate off by 20.1 percentage points, on the low side; measured number above the stated range.
By their numbers in this assay, from the lowest: compound 3; then compound 1; then compounds 4 and 2 (each within the scatter of the next).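

In this assay, among the compounds shown here, the one change that can be read directly, phenyl in place of (pyridin-2-yl)methyl on an amide-type nitrogen, gives a number 2.2 percentage points lower from compound 2 to compound 4 (within the scatter). At this position, then, the reading does not separate the two groups, even though the leaving group brings a ring nitrogen and a hydrogen-bond acceptor that the entering group lacks, and an aromatic ring set directly on the nitrogen need not come with a low reading. The compounds shown offer no information on why the two groups read alike.

On these data alone, whether this holds on the core of compound 1 or compound 3 remains open, as each differs from compound 4 in more than one place. Also open, as far as these compounds go, is how a longer chain on that nitrogen, or an amine or a carboxylic acid on the phenyl, would read.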